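This account rests on a few compounds, and the source may have more. Where it says the series, first, only, none or still open, it means among the compounds named here.

In a functional assay on HeLa cells (Homo sapiens) for antiproliferative activity, read by MTT assay, with a stated time of 24 h (a higher number here means a weaker inhibitor, a lower number a stronger inhibitor), compound 1 `O=[N+]([O-])c1ccc(CSc2nnc(-c3ccc4c(c3)OCCO4)n2-c2ccccc2)cc1` gives 36200 nM. Compound 3 `Cc1ccccc1CSc1nnc(-c2ccc3c(c2)OCCO3)n1-c1ccccc1` gives 36000 nM, and a 1.0-fold lower number from compound 1 to compound 3 (0.00 log units; within the scatter) stays within the scatter, so the two numbers stand level. Compound 2 `COc1cccc(CSc2nnc(-c3ccc4c(c3)OCCO4)n2-c2ccccc2)c1` reaches only a limit of the assay, > 100000 nM.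

Compound 4 `Fc1ccccc1CSc1nnc(-c2ccc3c(c2)OCCO3)n1-c1ccccc1` changes compound 1 on a saturated chain carbon bound to a sulfur: 2-fluorophenyl in place of 4-nitrophenyl on a saturated chain carbon bound to a sulfur. For the measured compounds named here, two measured steps bear on this change. Swapping in 2-methylphenyl gave a 1.0-fold lower number from compound 1 to compound 3 (0.00 log units; within the scatter), while swapping in 3-methoxyphenyl gave an at least 2.7-fold higher number from compound 1 to compound 2 (0.44 log units; beyond the scatter). The 2-methylphenyl step is the closer guide, so no change beyond the scatter is expected in this assay. The expected step is a 1.1-fold higher number from compound 1 to compound 4 (0.04 log units; within the scatter). Compound 4 is estimated at 40000 nM, with an expected range of 15000 nM to 100000 nM.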

Compound 4, half-maximal inhibitory concentration: 24300 nM
Compound 4: the middle estimate sits 1.6-fold (0.22 log units) above what was measured; measured number inside the range.
By their numbers in this assay, from the lowest: compounds 4, 3 and 1 (each within the scatter of the next). At a limit, above all of these: compound 2.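

In this assay, 2-fluorophenyl on a saturated chain carbon bound to a sulfur stands level with both earlier groups at this place, since a 1.5-fold lower number from compound 1 to compound 4 (0.17 log units; within the scatter) and a 1.5-fold lower number from compound 3 to compound 4 (0.17 log units; within the scatter) both stay within the scatter. Against 3-methoxyphenyl there is an at least 4.1-fold lower number from compound 2 to compound 4 (0.61 log units; beyond the scatter) and so a third compound now parts from compound 2. That step is read against a limit of the assay, not a number: the limit of > 100000 nM in this assay, at which 1 of the 4 values shown sits.

The compounds shown leave open whether an amine or a carboxylic acid on this ring, or a longer chain at this place, would move the number beyond the scatter.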